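From compound 3 to compound 4: one ring group exchanged

A few compounds are considered here, and "the series" means these few. Any claim that something is new, unique, unknown or untested is made for them only; others in the source may bear on it.

In a functional assay on HCT-15 cells (Homo sapiens) for cytotoxicity (on this read-out lower numbers stand for an effect already at smaller amounts and higher numbers for an effect only at larger amounts of compound), compound 3 (`COC1C=C(CCC/C(C)=C/C=C/[C@@H](C)CC/C=C(/C)C[C@H]2OC(=O)C(C)=C2O)C(=O)O1`) gives 33 ug/mL and serves as the reference point for this step. Compound 1 (`COC(=O)[C@H](O)C/C(C)=C\CC[C@H](C)/C=C/C=C(\C)CCCC1=CC(=O)O[C@H]1O`) gives 21.7 ug/mL and lies within the scatter of compound 3. Compound 2 (`C/C(=C\CCc1ccoc1)C[C@@H]1C=C(C/C=C/c2ccoc2)C(=O)O1`) gives 4.2 ug/mL which is a lower number than that of compound 3 by a margin beyond the scatter.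

Compound 4 (`CC1=C(O)[C@@H](C/C(C)=C\CC[C@H](C)/C=C/C=C(\C)CCCC2=CC(=O)N(CC(=O)O)C2)OC1=O`) keeps most of compound 3 and carries one change: a group of 10 heavy atoms (6 carbon, 1 nitrogen, 3 oxygen; one five-membered non-aromatic ring with 1 hetero atom) in place of a group of 8 heavy atoms (5 carbon, 3 oxygen; one five-membered non-aromatic ring with 1 hetero atom), on a saturated chain carbon, three bonds along the chain from a double-bonded chain carbon on a saturated chain carbon, three bonds along the chain from a double-bonded chain carbon.

Going by the values given here, no pair of measured compounds differs in one place only, so this change has no direct precedent in this assay and any expectation stays loose. The nearest guide is compound 1 at 21.7 ug/mL which shares a long chain with compound 3 and still stays within the scatter of it. Compound 2 at 4.2 ug/mL has a different chain and goes against reading the series as flat.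

No step beyond the scatter is expected, and the estimated step is a 1.1-fold higher number from compound 3 to compound 4 (0.03 log units; within the scatter) with no firm direction. For compound 4 the estimated value is 35 ug/mL with an expected range from 12 ug/mL to 100 ug/mL as the working estimate.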

Compound 4, concentration for half-maximal effect: > 30 ug/mL
Compound 4: only a limit was reported; the forecaster's own chance of this, stated with the estimate: 25%; the middle value does not contradict the limit.
By their numbers in this assay, from the lowest: compound 2; then compounds 1 and 3 (each within the scatter of the next).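

In this assay compound 4 gives > 30 ug/mL as a limit and not a number. No new step can be read from this result, so the comparison of compound 3 with compound 4 stays without a size. The compounds shown leave open how far, and in which direction, this ring group exchange shifts the cytotoxicity read-out.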